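A few compounds are considered here, and "the series" means these few. Any claim that something is new, unique, unknown or untested is made for them only; others in the source may bear on it.

Measured so far:
compound 1 `CC(=O)c1cc(CC(C)O)c(OCCCCC#N)cc1O` gives 10% in an assay on isolated protein for inhibition of leukotriene B4 receptor 1 (Homo sapiens), tested at 10 uM; a higher number here means more inhibition at the concentration tested (going by the name of the read-out), a lower number less inhibition
compound 2 `C=CCc1cc(C(C)=O)c(O)cc1OCCCCCCCCCCC#N` gives 50% in this assay
compound 3 `CC(=O)c1cc(C(C)(C)C)c(OCCCCCC(C)(C)C#N)cc1O` gives 1% in this assay

Compound 2 holds the highest of the three numbers in this assay; compound 1 lies a gap below it that exceeds the scatter, and compound 3 lies further below, also beyond the scatter. Compound 4 `C=CCc1cc(C(C)=O)c(O)cc1OCCCCCC(C)=O` has not yet been measured. Its difference from compound 2: acetyl in place of 5-cyanopentyl on a saturated chain carbon, five bonds along the chain from an oxygen on an aromatic ring. Among the measured compounds shown here, no pair of measured compounds shares this change, so the expectation rests on the spread seen. Compound 1 gives 10%, while compound 2 gives the top number; compound 3, however, gives 1% and does not fit a simple chain reading. Compound 4 is expected to fall below compound 2, with a step of a number 30 percentage points lower from compound 2 to compound 4 (beyond the scatter). Compound 4 is estimated at 20%, within 5% to 40%.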

Compound 4, a percentage reported as inhibition, at one concentration (the size of the read-out at that concentration, not a potency): 98%
Estimate against measurement, compound 4: 78 percentage points below; the measured number lies above the stated range.
By their numbers in this assay, from the lowest: compounds 3 and 1 (each within the scatter of the next); then compound 2; then compound 4.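

In this assay, among the compounds shown here, acetyl in place of 5-cyanopentyl, on a saturated chain carbon, five bonds along the chain from an oxygen on an aromatic ring, gives a step of a number 48 percentage points higher from compound 2 to compound 4 (beyond the scatter) in the first one-place comparison of the series. The nitrile is therefore not required at this position, and a group of 3 heavy atoms in place of 7 can raise the number. Nothing at hand accounts for the gain.

Still open, from the compounds shown here alone, is whether the gain follows the carbonyl or the smaller group, as both change together. A longer chain ending in acetyl, or a carboxylic acid or an amine at this position, would help separate the two.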